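From Butyl to Isobutyl: Same Atoms, Rearranged Chain

The source may report more compounds than this note shows. Statements on the series, on what has been measured and on what is new or still open speak of the compounds shown alone.

- compound 1 `CCOC(=O)c1cc(N2C(=O)C3=C(CCCC3)C2=O)c(F)cc1Cl`: 57.5 nM
- compound 2 `CCCOC(=O)c1cc(N2C(=O)C3=C(CCCC3)C2=O)c(F)cc1Cl`: 33.1 nM
- compound 3 `CCCCOC(=O)c1cc(N2C(=O)C3=C(CCCC3)C2=O)c(F)cc1Cl`: 126 nM

In a functional assay on the whole organism for inhibition, with Scenedesmus acutus as the target (on this read-out higher numbers stand for weaker inhibition and lower numbers for stronger inhibition), compound 3 has the highest number of the three, making it the weakest inhibitor here. Compound 4 `CC(C)COC(=O)c1cc(N2C(=O)C3=C(CCCC3)C2=O)c(F)cc1Cl` has the same atoms, joined differently: isopropyl in place of propyl on a saturated chain carbon bound to an oxygen next to a carbonyl group. For the measured compounds named here, the only guides are steps that lengthen the chain: a 1.7-fold lower number from compound 1 to compound 2 (0.24 log units; within the scatter), then a 3.8-fold higher number from compound 2 to compound 3 (0.58 log units; beyond the scatter), and overall a 2.2-fold higher number from compound 1 to compound 3 (0.34 log units; beyond the scatter). No branched chain has been measured, so these steps offer only loose guidance. A small move back towards the other two compounds is expected, and it may not clear the scatter. The expected step is a 1.7-fold lower number from compound 3 to compound 4 (0.23 log units; within the scatter). Compound 4 is estimated at 75 nM, with an expected range of 32 nM to 175 nM.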

Compound 4, half-maximal inhibitory concentration: 100 nM
Compound 4: the middle estimate sits 1.3-fold (0.12 log units) below what was measured; measured number inside the range.
By their numbers in this assay, from the lowest: compounds 2, 1, 4 and 3 (each within the scatter of the next, the first and the last beyond it).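

In this assay, rearranging the butyl chain into isobutyl gives a 1.3-fold lower number from compound 3 to compound 4 (0.10 log units; within the scatter), so at this position branching makes no clear difference. Adding the extra carbon to the propyl chain as a branch gives a 3.0-fold higher number from compound 2 to compound 4 (0.48 log units; beyond the scatter), so the branched chain, like the straight butyl chain, lies beyond the scatter from the propyl compound. Against the shortest chain shown, the step is a 1.7-fold higher number from compound 1 to compound 4 (0.24 log units; within the scatter).

Nothing measured here explains these numbers. On these data alone, how a pentyl chain or a benzyl group would behave at this position remains open.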